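This account rests on a few compounds, and the source may have more. Where it says the series, first, only, none or still open, it means among the compounds named here.

Working notes on the series. In an assay on HEK293 cells for displacement of a labelled ligand from Urotensin-2 receptor (Homo sapiens) (on this read-out higher numbers stand for weaker inhibition and lower numbers for stronger inhibition), compound 1 `Cn1ccc2c(NC(=O)NCCN3CCC(O)(Cc4ccccc4)CC3)ccnc21` gives 160 nM. Compound 2 `Cn1ccc2nccc(NC(=O)NCCN3CCC(O)(Cc4ccccc4)CC3)c21` gives 600 nM in this assay, and compound 3 `O=C(NCCN1CCC(O)(Cc2ccccc2)CC1)Nc1ccnc2ccoc12` gives 450 nM in this assay. Compound 3 stands second highest of the three numbers: its nearest neighbour is compound 2, the step of a 1.3-fold lower number from compound 2 to compound 3 (0.12 log units; within the scatter) lying within the scatter, while the step of a 2.8-fold higher number from compound 1 to compound 3 (0.45 log units; beyond the scatter) lies beyond it. The three measured compounds differ only in the bicyclic group attached to the amide-type nitrogen of the shared core.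

Compound 4 `Cc1cc2nccc(NC(=O)NCCN3CCC(O)(Cc4ccccc4)CC3)c2s1` has not been measured. Relative to compound 3 the change is a group of 10 heavy atoms (8 carbon, 1 nitrogen, 1 sulfur; one five-membered aromatic ring with 1 hetero atom, one six-membered aromatic ring with 1 hetero atom) in place of a group of 9 heavy atoms (7 carbon, 1 nitrogen, 1 oxygen; one five-membered aromatic ring with 1 hetero atom, one six-membered aromatic ring with 1 hetero atom), on an amide-type nitrogen. The measured steps that bear on it are swaps of the same kind at the same nitrogen: a 3.8-fold higher number from compound 1 to compound 2 (0.57 log units; beyond the scatter), a 2.8-fold higher number from compound 1 to compound 3 (0.45 log units; beyond the scatter) and a 1.3-fold lower number from compound 2 to compound 3 (0.12 log units; within the scatter). None of these went beyond a modest size, and one stayed within the scatter. For compound 4 in this assay the expected step is therefore modest at most, with no clear direction to be read from three points, and the estimate amounts to the step of a 1.3-fold lower number from compound 3 to compound 4 (0.11 log units; within the scatter). Compound 4 is expected to give about 350 nM in this assay, with a range from 120 nM to 1000 nM.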

Compound 4, half-maximal inhibitory concentration: 78 nM
Compound 4: middle estimate off by 4.5-fold (0.65 log units), on the high side; the measured number lies below the stated range.
By their numbers in this assay, from the lowest: compound 4; then compound 1; then compounds 3 and 2 (each within the scatter of the next).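

The sulfur-containing group takes the series below its earlier lowest value, with a 2.1-fold lower number from compound 1 to compound 4 (0.31 log units; beyond the scatter), so the bicyclic group on this amide-type nitrogen can strengthen inhibition in this assay as well as weaken it relative to compound 1. The other two steps, a 5.8-fold lower number from compound 3 to compound 4 (0.76 log units; beyond the scatter) and a 7.7-fold lower number from compound 2 to compound 4 (0.89 log units; beyond the scatter), are both larger than any step among the first three compounds, which shows that this place is more sensitive to the swap than those compounds suggested, even though the leaving and entering groups of the step from compound 3 have the same ring types and the same counts of hydrogen-bond donors and acceptors. No measurement available here accounts for the size of these steps.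

The entering group differs from the leaving group in both its sulfur and its additional carbon, and the compounds shown do not separate the two contributions. Also open, on these data alone, is whether the value would hold with an ethyl group, an amine or a carboxylic acid on the bicyclic group.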